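Adding a methoxyphenyl to the amine arm of compound 3

The source may hold more compounds than are shown below. What is called first, only, known or untested is meant among the compounds shown, and "the series" means these compounds.

The series rests on a shared diaryl ether core bearing a benzylamine arm. Compound 1 `COc1ccc(CCCNCc2c(OC)cc(Oc3ccc(Nc4ccccc4)cc3)cc2OC)cc1` carries a longer chain to a methoxyphenyl and gives 4650 nM in a functional assay on DLD-1 cells (Homo sapiens) for inhibition, read by MTT assay, with a stated time of 72 h; a lower number here means a stronger inhibitor, a higher number a weaker inhibitor. Compound 2 `COc1cc(Oc2cccc(Nc3ccccc3)c2)cc(OC)c1CNCc1ccc(Br)cc1` carries a bromophenyl on the amine arm and gives 3520 nM in this assay. Compound 3 `CNCc1c(OC)cc(Oc2cccc(Nc3ccccc3)c2)cc1OC` is the simplest of the three and gives 11900 nM in this assay, the highest of the three numbers, with compound 1 nearest and compound 2 furthest.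

Compound 4 `COc1ccc(CNCc2c(OC)cc(Oc3cccc(Nc4ccccc4)c3)cc2OC)cc1` differs from compound 3 in one place: 4-methoxyphenyl in place of hydrogen on a saturated chain carbon bound to an amine nitrogen. Within the data shown here, the only measured step at this same place runs the other way, where removing the aryl group gave a 3.4-fold higher number from compound 2 to compound 3 (0.53 log units; beyond the scatter). Compound 1 shows that a methoxyphenyl on the amine arm is compatible with a number below that of compound 3, though its chain and ring pattern differ, so it is not a direct step. The step into compound 4 is therefore expected to lower the number in this assay by roughly the size seen before, that is a 3.4-fold lower number from compound 3 to compound 4 (0.53 log units; beyond the scatter). Compound 4 is estimated at 3500 nM, within a range from 1500 nM to 8000 nM.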

Compound 4, half-maximal inhibitory concentration: 1910 nM
Estimate against measurement, compound 4: 1.8-fold (0.26 log units) above, within the range that was stated.
By their numbers in this assay, from the lowest: compounds 4, 2 and 1 (each within the scatter of the next, the first and the last beyond it); then compound 3.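

In this assay, the change to 4-methoxyphenyl in place of hydrogen on a saturated chain carbon bound to an amine nitrogen gives a 6.2-fold lower number from compound 3 to compound 4 (0.79 log units; beyond the scatter), so the lower number seen at this place with 4-bromophenyl is now seen with a second aryl group and does not rest on a single example. With methoxy in place of bromo on an aromatic carbon, the result is a 1.8-fold lower number from compound 2 to compound 4 (0.27 log units; within the scatter), which means that these two compounds cannot be told apart and that this swap on the ring leaves the number unchanged as far as the scatter allows. Nothing available explains why an aryl group at this place lowers the number.

The compounds shown leave open whether an unsubstituted phenyl, or a ring carrying a nitrile or a carboxylic acid, would read like compound 2 and compound 4. Among these compounds, they also leave open what a longer chain between the amine and the ring does, since compound 1 differs from compound 4 in more than one place and gives no clean step.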